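Replacing 4-ethylphenyl with 3-fluorophenyl on a sulfur

The source may hold more compounds than are shown below. What is called first, only, known or untested is meant among the compounds shown, and "the series" means these compounds.

Measured so far in a functional assay on A549 cells (Homo sapiens) for inhibition, read by CCK-8 assay, with a stated time of 72 h, tested at 2 uM; a higher number here means more inhibition of growth at the concentration tested, a lower number less inhibition of growth:
compound 1 `Nc1ccccc1NC(=O)/C=C/c1ccc(CSc2cccc(F)c2)cc1` gives 50.7%
compound 2 `COc1ccc(SCc2ccc(C(=O)Nc3ccccc3N)cc2)cc1` gives 45.7%
compound 3 `CCc1ccc(SCc2ccc(C(=O)Nc3ccccc3N)cc2)cc1` gives 53.6%

Compound 3 stands at 53.6%, within the scatter of both compound 1 and compound 2. Compound 4 `Nc1ccccc1NC(=O)c1ccc(CSc2cccc(F)c2)cc1` differs from it by 3-fluorophenyl in place of 4-ethylphenyl on a sulfur. Within the data shown here, the only measured step in this part of the structure, ethyl in place of methoxy on an aromatic carbon, is a number 7.9 percentage points higher from compound 2 to compound 3 (within the scatter). Compound 1 also carries 3-fluorophenyl on a sulfur, on a different core, and gives 50.7%. On this evidence, an expected step of a number 3.6 percentage points lower from compound 3 to compound 4 (within the scatter) would stay within the scatter. For compound 4 the estimated value in this assay is 50%, with an expected range of 38% to 62%.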

Compound 4, percent growth inhibition at one concentration: 46.9%
For compound 4 the middle estimate is 3.1 percentage points above the measured one, within the range that was stated.
By their numbers in this assay, from the lowest: compounds 2, 4, 1 and 3 (each within the scatter of the next).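

In this assay, the change on the sulfur gives a number 6.7 percentage points lower from compound 3 to compound 4 (within the scatter) and a number 1.2 percentage points higher from compound 2 to compound 4 (within the scatter), so on the shared core 3-fluorophenyl stands within the scatter of both 4-ethylphenyl and 4-methoxyphenyl. Among these compounds, this is the first reading of a fluorine-bearing ring at this position on that core, and neither step goes beyond the scatter. No measurement bears on why these numbers lie so close.

From the compounds shown here alone, whether a phenyl ring carrying an amine or a carboxylic acid, or a longer chain in place of the ring, would also stay within the scatter remains open.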